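The source may hold more compounds than are shown below. What is called first, only, known or untested is meant among the compounds shown, and "the series" means these compounds.

Compound 1 `O=C(/C=C/c1ccco1)c1cccc(OCC2CO2)c1`: 28.5%
Compound 2 `O=C(/C=C/c1cccs1)c1cccc(OCC2CO2)c1`: 2.7%
Compound 3 `O=C(/C=C/c1ccco1)c1ccc(OCC2CO2)cc1`: 36.8%

In an assay for inhibition of DNA topoisomerase 1 (Homo sapiens), with a stated time of 30 min, tested at 100 uM (a lower number here means a weaker effect, a higher number a stronger effect of the compound at the concentration tested), compound 3 holds the highest of the three numbers, though compound 1 lies within the scatter of it; only compound 2 lies clearly lower, beyond the scatter. Compound 4 `O=C(/C=C/c1ccoc1)c1ccc(OCC2CO2)cc1` differs from compound 3 by furan-3-yl in place of furan-2-yl on a double-bonded chain carbon bound to a double-bonded chain carbon. Within the data shown here, the single measured step at that place, a number 25.8 percentage points lower from compound 1 to compound 2 (beyond the scatter), exchanged one five-membered aromatic ring for another; the present change keeps the same ring and the same atoms, joined differently, and no measured pair shows it directly. A step within the scatter, or at most a modest fall, is therefore expected: a number 10.8 percentage points lower from compound 3 to compound 4 (beyond the scatter). Compound 4 is estimated at 26%, with a range from 5% to 45%.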

Compound 4, a percentage reported as inhibition, at one concentration (the size of the read-out at that concentration, not a potency): 5.6%
Beside the measured number, compound 4's estimate is 20.4 percentage points above it; the range from low to high includes it.
By their numbers in this assay, from the lowest: compounds 2 and 4 (each within the scatter of the next); then compounds 1 and 3 (each within the scatter of the next).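

Keeping the same ring and the same atoms while changing only how the furan is joined to the chain gives a number 31.2 percentage points lower from compound 3 to compound 4 (beyond the scatter) in this assay. The earlier step at this place exchanged furan-2-yl for thiophen-2-yl, so it could not show that the point of attachment alone can matter this much. No measurement shown here explains this drop.

From the compounds shown here alone, it remains open whether the same change on the core of compound 1 gives a similar step. Going by these compounds, how a phenyl ring or a thiophen-3-yl group would behave at this place is also open.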